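This account rests on a few compounds, and the source may have more. Where it says the series, first, only, none or still open, it means among the compounds named here.

Working notes on the series. Three compounds share the same core and differ only at the group on the amine nitrogen of the six-membered ring. Compound 1 `CC1(OC(=O)N2CCC(O[C@H]3CC[C@H](Oc4cnc(S(C)(=O)=O)cn4)CC3)CC2)CC1` gives 138 nM in a functional assay on isolated protein for agonist activity at Glucose-dependent insulinotropic receptor (Rattus norvegicus), read by HTRF and cAMP accumulation; a lower number here means that less compound is needed, a higher number that more compound is needed for the effect. Compound 2 `CS(=O)(=O)c1cnc(O[C@H]2CC[C@H](OC3CCN(C(=O)Oc4ccccc4)CC3)CC2)cn1` gives 71.8 nM, and compound 3 `CS(=O)(=O)c1cnc(O[C@H]2CC[C@H](OC3CCN(C(=O)C4(C(F)(F)F)CC4)CC3)CC2)cn1` gives 1380 nM; compound 3 stands highest of the three numbers, with a 10-fold higher number from compound 1 to compound 3 (1.00 log units; beyond the scatter) and a 19-fold higher number from compound 2 to compound 3 (1.28 log units; beyond the scatter), while a 1.9-fold lower number from compound 1 to compound 2 (0.28 log units; within the scatter).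

Compound 4 `CS(=O)(=O)c1cnc(O[C@H]2CC[C@H](OC3CCN(CC4(C(F)(F)F)CC4)CC3)CC2)cn1` takes the next step from compound 3: (1-(trifluoromethyl)cyclopropyl)methyl in place of (1-(trifluoromethyl)cyclopropyl)carbonyl on an amine nitrogen in a ring. Going by the values given here, no measured step removes the carbonyl, so no step bears on it directly. Among the compounds with values here, the steps from compound 1 and compound 2 to compound 3 show only that swapping the group on the carbonyl carbon moves this assay by a modest to large amount, and both moves were toward higher numbers as the oxygen on the carbonyl was lost. On that thin basis, a further step toward a higher number is expected for compound 4, of about a 2.9-fold higher number from compound 3 to compound 4 (0.46 log units; beyond the scatter), with wide uncertainty. Compound 4 is estimated at 4000 nM, in the range 700 nM to 20000 nM.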

Compound 4, half-maximal effective concentration: 163 nM
Estimate against measurement, compound 4: 25-fold (1.39 log units) above; measured number outside the range, below it.
By their numbers in this assay, from the lowest: compounds 2, 1 and 4 (each within the scatter of the next, the first and the last beyond it); then compound 3.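

At the amine nitrogen of the six-membered ring, a carbonyl is not needed for a low number in this assay: (1-(trifluoromethyl)cyclopropyl)methyl in place of (1-(trifluoromethyl)cyclopropyl)carbonyl gives an 8.5-fold lower number from compound 3 to compound 4 (0.93 log units; beyond the scatter) and shows that the 1-(trifluoromethyl)cyclopropyl unit alone does not carry the high number of compound 3. The carbonyl-free group matches ((1-methylcyclopropyl)oxy)carbonyl with a 1.2-fold higher number from compound 1 to compound 4 (0.07 log units; within the scatter) but does not reach phenoxycarbonyl, with a 2.3-fold higher number from compound 2 to compound 4 (0.36 log units; beyond the scatter). No measurement to hand accounts for these steps.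

The compounds shown leave open whether a longer chain, such as 2-(1-(trifluoromethyl)cyclopropyl)ethyl, would hold the number of compound 4. They also leave open whether a benzyl group on this nitrogen would come closer to compound 2 than the (1-(trifluoromethyl)cyclopropyl)methyl group does.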